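The source may hold more compounds than are shown below. What is called first, only, known or untested is meant among the compounds shown, and "the series" means these compounds.

Compound 3 `CC(C)(C)c1cc2nn(-c3ccccc3)c(N)c2c(=O)[nH]1` is the second highest of the three numbers recorded in an assay on isolated protein for inhibition of protein kinase C zeta type (Homo sapiens), read by mobility shift assay, tested at 30 uM; on this read-out lower numbers stand for less inhibition and higher numbers for more inhibition at the one concentration tested (going by the name of the read-out). The nearest to it is compound 1 `COc1ccc(-c2cc3[nH]nc(N)c3c(=O)[nH]2)cc1`, which in this assay gives 7%, a number within the scatter of compound 3, which gives -1%. The furthest is compound 2 `Cc1cc2nn(-c3ccccc3)c(N)c2c(=O)[nH]1`, which in this assay gives -49%, far below. Within the data shown here, the only step measured between compounds that differ in one place is the one a number 48 percentage points higher from compound 2 to compound 3 (beyond the scatter), so a change at this carbon has once moved the number a great deal. Compound 4 `Nc1c2c(=O)[nH]c(-c3ccccc3)cc2nn1-c1ccccc1` differs from compound 3 by phenyl in place of tert-butyl on an aromatic carbon. Among the measured compounds shown here, no measured step swaps tert-butyl for phenyl, so that step supplies no direct guide; compound 1, which also carries an aromatic ring on the shared core in this position, sits within the scatter of compound 3, which points to a small step at most. Compound 3 is therefore expected to move only by a number 5 percentage points higher from compound 3 to compound 4 (within the scatter). Compound 4 is estimated at 4%, between -28% and 30%.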

Compound 4, a percentage reported as inhibition, at one concentration (the size of the read-out at that concentration, not a potency): -163%
For compound 4 the middle estimate is 167 percentage points above the measured one; measured number outside the range, below it.
By their numbers in this assay, from the lowest: compound 4; then compound 2; then compounds 3 and 1 (each within the scatter of the next).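

In this assay, the aromatic carbon next to the ring nitrogen proves able to move the number far downward as well as upward: phenyl in place of tert-butyl gives a number 162 percentage points lower from compound 3 to compound 4 (beyond the scatter) and phenyl in place of methyl gives a number 114 percentage points lower from compound 2 to compound 4 (beyond the scatter) on the shared core. Set beside a number 48 percentage points higher from compound 2 to compound 3 (beyond the scatter), these steps show that replacing methyl at this carbon has no single direction, since tert-butyl raises the number and phenyl lowers it. No measurement at hand gives a reason for these steps.

The compounds shown leave open whether the low number goes with any ring at this carbon or with phenyl alone, as a pyridine ring or a cyclohexyl group would test. They also leave open whether an amine, a carboxylic acid or a longer alkyl chain here would stand nearer tert-butyl or phenyl.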